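Swapping a propyl for methoxy on a macrolide side chain

The source may hold more compounds than are shown below. What is called first, only, known or untested is meant among the compounds shown, and "the series" means these compounds.

Of the compounds shown here, three have been measured in a physicochemical assay for lipophilicity, read by HPLC, measured as chromatographic lipophilicity, at pH 7.4; on this read-out higher numbers stand for higher lipophilicity and lower numbers for lower lipophilicity. Compound 1, `CCCCCCCC(=O)NCCCN1C[C@H](C)C[C@@](C)(O)[C@H](O)[C@@H](C)[C@H](O)[C@@H](C)C(=O)O[C@H](CC)[C@@](C)(O)[C@H](O)[C@H]1C`, gives 3.49. Compound 2, `CCCCC(=O)NCCCO[C@@H]1[C@@H](C)N(C)C[C@H](C)C[C@@](C)(O)[C@H](O[C@@H]2O[C@H](C)C[C@H](N(C)C)[C@H]2O)[C@@H](C)[C@H](O[C@H]2C[C@@](C)(OC)[C@@H](O)[C@H](C)O2)[C@@H](C)C(=O)O[C@H](CC)[C@@]1(C)O`, gives 3.74. Compound 3, `CCCCCCCC(=O)NCCCO[C@@H]1[C@@H](C)C(=O)[C@H](C)C[C@@](C)(OC)[C@H](O[C@@H]2O[C@H](C)C[C@H](N(C)C)[C@H]2O)[C@@H](C)[C@H](O[C@H]2C[C@@](C)(OC)[C@@H](O)[C@H](C)O2)[C@@H](C)C(=O)O[C@H](CC)[C@@]1(C)O`, gives 5.07. Among these three numbers compound 2 stands second highest: its value and that of compound 1 lie within the usual scatter of each other, so no order between them can be claimed, while compound 3 sits well beyond the scatter on the higher side.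

Compound 4, `CC[C@H]1OC(=O)[C@H](C)[C@@H](O[C@H]2C[C@@](C)(OC)[C@@H](O)[C@H](C)O2)[C@H](C)[C@@H](O[C@@H]2O[C@H](C)C[C@H](N(C)C)[C@H]2O)[C@](C)(O)C[C@@H](C)CN(C)[C@H](C)[C@@H](OCCCNC(=O)COC)[C@]1(C)O`, has not yet been measured. It differs from compound 2 in one place: methoxy in place of propyl on a saturated chain carbon bound to a carbonyl carbon. For the measured compounds named here, no measured pair in this set shows that same exchange, so its effect must be estimated rather than read off. The shift from compound 2 to compound 4 in this assay is expected to be a downward step beyond the scatter, of about a number 1.24 log units lower from compound 2 to compound 4 (beyond the scatter). On that basis compound 4 is estimated to give 2.5, with a likely range from 1.9 to 3.1.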

Compound 4, distribution coefficient: 2.58
Compound 4: the middle estimate sits 0.08 log units below what was measured; measured number inside the range.
By their numbers in this assay, from the lowest: compound 4; then compounds 1 and 2 (each within the scatter of the next); then compound 3.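

In this assay, for the compounds shown here, methoxy in place of propyl on a saturated chain carbon bound to a carbonyl carbon gives a number 1.16 log units lower from compound 2 to compound 4 (beyond the scatter) and so provides the first direct reading of this exchange at this place. The step is large for a small edit, in which the 3 heavy atoms of propyl, all carbon, give way to the 2 heavy atoms of methoxy, with 1 hydrogen-bond acceptor. Nothing available explains why the number moves this far.

The compounds shown leave open how much of the step goes with the oxygen and how much with the shorter chain, which a plain ethyl group at this place would help to separate. Also open, on these data alone, are how an amine would read here and whether methoxy gives a similar step on the core of compound 1 or compound 3.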